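The source may hold more compounds than are shown below. What is called first, only, known or untested is meant among the compounds shown, and "the series" means these compounds.

Measured so far:
Compound 1, `O=C1COc2ccc(-c3cccc(NS(=O)(=O)c4ccc(F)cc4)c3)cc2N1C1CC1`: > 40000 nM, a limit of the assay.
Compound 2, `O=C1COc2ccc(-c3cnc4ccccc4c3)cc2N1c1ccccc1`: > 40000 nM, also a limit.
Compound 3, `CC(C)N1C(=O)COc2ccc(-c3cccc(NS(=O)(=O)c4ccc(F)cc4)c3)cc21`: 26000 nM.

Within the data shown here, in a functional assay on MCF7 cells (Homo sapiens) for antiproliferative activity, read by MTT assay, with a stated time of 72 h (a higher number here means a weaker inhibitor, a lower number a stronger inhibitor), compound 3 is the only compound with a real number. Compound 1 and compound 2 sit at the limit of > 40000 nM in this assay, at which 2 of the 3 values shown sit, so nothing can be said about their order relative to each other. Among the measured compounds shown here, the one step that can be measured runs from compound 1 to compound 3: an at least 1.5-fold lower number from compound 1 to compound 3 (0.18 log units; that floor lies within the scatter). It is a small change, and its floor lies within the scatter.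

Compound 4, `O=C1COc2ccc(-c3cccc(NS(=O)(=O)c4ccc(F)cc4)c3)cc2N1c1ccc(F)cc1`, takes the next step: 4-fluorophenyl in place of isopropyl on an amide-type nitrogen in a ring. For the measured compounds named here, no measured step swaps an alkyl group for an aromatic ring on this nitrogen, so the step from compound 1 to compound 3 is only a weak guide. Compound 2 carries a plain phenyl on the same nitrogen, but it also differs elsewhere, and it shows only a limit. Taken together, the sparse data give no reason to expect a change beyond the scatter in either direction, while a slide to the limit cannot be ruled out. Compound 4 is therefore expected to give about 30000 nM, within a range from 10000 nM to 60000 nM. That amounts to an expected step of a 1.2-fold higher number from compound 3 to compound 4 (0.06 log units; within the scatter).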

Compound 4, half-maximal inhibitory concentration: > 40000 nM
Compound 4: a limit, no number (the forecaster's own chance of this, stated with the estimate: 40%); middle value at least 1.3-fold (0.12 log units) from the limit.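

In this assay, among these compounds, this is the first measured step on this amide-type nitrogen that puts an aromatic ring in place of an alkyl group, and it reads as an at least 1.5-fold higher number from compound 3 to compound 4 (0.18 log units; that floor lies within the scatter). With 4-fluorophenyl on this nitrogen, no readable number appears, so the change brings no measurable gain in this series, while the floor of the step alone does not establish a real loss. Among the compounds shown here, compound 3, with its isopropyl group, remains the only compound here with a real number, and the step from the cyclopropyl compound, compound 1, to compound 4 cannot be read, as both of its ends are limits: the limit of > 40000 nM in this assay, at which 3 of the 4 values shown sit.

Going by these compounds, it remains open whether a plain phenyl group on this nitrogen, with the rest of compound 3 unchanged, would behave like 4-fluorophenyl, which would separate the effect of the ring from that of the fluorine. Also open, on these data alone, is how a methyl group, a longer chain such as n-butyl, or a chain ending in an amine or a carboxylic acid at this place would read in this assay.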